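A few compounds are considered here, and "the series" means these few. Any claim that something is new, unique, unknown or untested is made for them only; others in the source may bear on it.

Measured so far:
- Compound 1 `Fc1cccc(-c2nc(Nc3ccccc3)c3cc(F)ccc3n2)c1`: 48300 nM
- Compound 2 `Fc1cccc(-c2nc(Nc3cccc(Br)c3)c3cc(F)ccc3n2)c1`: a limit, > 50000 nM
- Compound 3 `Nc1cccc(Nc2nc(-c3cccc(F)c3)nc3ccc(F)cc23)c1`: a limit, > 50000 nM

For the measured compounds named here, in a functional assay on HL-60 cells (Homo sapiens) for cytotoxicity, read by MTT assay, with a stated time of 48 h (on this read-out higher numbers stand for weaker inhibition and lower numbers for stronger inhibition), compound 1 gives 48300 nM, and that is the only plain number among the three compounds. The value of compound 2 is a limit of the assay. The value of compound 3 is a limit of the assay too. Both of them sit at the limit of > 50000 nM in this assay, at which 2 of the 3 values shown sit.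

Compound 4 `Cc1cccc(Nc2nc(-c3cccc(F)c3)nc3ccc(F)cc23)c1` differs from compound 1 by methyl in place of hydrogen on an aromatic carbon. Two measured steps start from compound 1 and change the same aromatic carbon: an at least 1.0-fold higher number from compound 1 to compound 2 (0.01 log units; that floor lies within the scatter), and an at least 1.0-fold higher number from compound 1 to compound 3 (0.01 log units; that floor lies within the scatter). Neither reveals a step beyond the scatter; each only says the number did not fall. A methyl group entering at that carbon is therefore expected to give no step beyond the scatter, with a real chance that only a limit is reported. Compound 4 is accordingly expected to give about 55000 nM, within 25000 nM to 120000 nM. The step this estimate means, a 1.1-fold higher number from compound 1 to compound 4 (0.06 log units; within the scatter), is expected to stay within the scatter.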

Compound 4, half-maximal inhibitory concentration: > 50000 nM
Compound 4 was reported as a limit (the forecaster's own chance of this, stated with the estimate: 55%); the middle value lies beyond the limit too.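

In this assay, methyl joins bromo and amino as a third group tried on this aromatic carbon, meta to a large group, and the step reads an at least 1.0-fold higher number from compound 1 to compound 4 (0.01 log units; that floor lies within the scatter). None of the three groups brings the number down from that of compound 1, so this carbon has shown no gain in inhibition so far, and compound 4 joins compounds 2 and 3 at a limit of the assay: the limit of > 50000 nM in this assay, at which 3 of the 4 values shown sit. The steps among compounds 2, 3 and 4 cannot be read, so these three groups cannot be ranked against one another.

On these data alone, it remains open whether a methoxy group, a carboxylic acid or a longer chain on this carbon would lower the number. As far as these compounds go, it is also open whether a change elsewhere on the core of compound 1 would move the number beyond the scatter.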